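Swapping the aryl group on the shared core

The source may report more compounds than this note shows. Statements on the series, on what has been measured and on what is new or still open speak of the compounds shown alone.

Compound 1 `Cc1ccc(C2C(C#N)=C(N)N(c3ccc(S(N)(=O)=O)cc3)C3=C2C(=O)CCC3)cc1` stands highest of the three measured compounds: in a functional assay on Ehrlich cells (Mus musculus) for antiproliferative activity, read by trypan blue exclusion, with a stated time of 2 h, tested at 10 ug/mL (on this read-out lower numbers stand for a weaker effect and higher numbers for a stronger effect at the one concentration tested), compound 1 gives 30%. In this assay compound 2 `N#CC1=C(N)N(c2ccc(S(N)(=O)=O)cc2)C2=C(C(=O)CCC2)C1/C=C/c1ccccc1` gives 2% and compound 3 `COc1ccccc1C1C(C#N)=C(N)N(c2ccc(S(N)(=O)=O)cc2)C2=C1C(=O)CCC2` gives 0%. Compound 4 `COc1cc(CC2C(C#N)=C(N)N(c3ccc(S(N)(=O)=O)cc3)C3=C2C(=O)CCC3)ccc1O` has not been measured; it differs from compound 1 in one place: 4-hydroxy-3-methoxybenzyl in place of 4-methylphenyl on a saturated ring carbon. Two measured steps change the same group on the same saturated ring carbon: a number 28 percentage points lower from compound 1 to compound 2 (beyond the scatter) and a number 30 percentage points lower from compound 1 to compound 3 (beyond the scatter), both modest drops beyond the scatter. Each replacement of the 4-methylphenyl group seen so far lowered the read-out, so a similar fall is expected for compound 4, with a number 25 percentage points lower from compound 1 to compound 4 (beyond the scatter). Compound 4 is therefore estimated at 5%, in a range from 0% to 20%.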

Compound 4, a percentage reported as activity, at one concentration (the size of the read-out at that concentration, not a potency): 0%
The estimate for compound 4 lay 5 percentage points above the measured number, and the stated range covers the measured number.
By their numbers in this assay, from the lowest: compounds 3, 4 and 2 (each within the scatter of the next); then compound 1.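

In this assay a third replacement of 4-methylphenyl also lowers the read-out (a number 30 percentage points lower from compound 1 to compound 4 (beyond the scatter)), so the drop now covers a benzyl group as well as 2-methoxyphenyl and 2-phenylethenyl. The three replacements cannot be told apart, with no change at the digits printed from compound 3 to compound 4 (within the scatter) and a number 2 percentage points lower from compound 2 to compound 4 (within the scatter) both within the scatter. No measurement here explains why 4-methylphenyl stands above them. The compounds shown leave open whether any other group on this saturated ring carbon, such as an amine, a carboxylic acid or a longer alkyl chain, would match or exceed compound 1.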